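Estimating compound 4 without a number for compound 3

The source may hold more compounds than are shown below. What is called first, only, known or untested is meant among the compounds shown, and "the series" means these compounds.

Measured so far in a physicochemical assay for lipophilicity, read by HPLC, in phosphate buffer, measured as octanol-water partition, at pH 7.4, tested at 100 uM (a lower number here means a more polar compound, a higher number a more lipophilic compound), for three compounds:
- compound 1 `O=C(O)COc1ccc(NCc2cccc(-c3ccccc3Cl)c2)cc1F` reads 2.71
- compound 2 `Cc1ccccc1-c1cccc(CNc2ccc(OCC(=O)O)c(F)c2)c1` reads 2.41
- compound 3 `N#Cc1ccccc1-c1cccc(CNc2ccc(OCC(=O)O)c(F)c2)c1` reads "not determined" (no result reported)

Compound 3 has no number, so it offers no starting point. Compound 4 `Cc1cc(O)ccc1-c1cccc(CNc2ccc(OCC(=O)O)c(F)c2)c1` differs from it by this exchange: 4-hydroxy-2-methylphenyl in place of 2-cyanophenyl on an aromatic carbon with 4-hydroxy-2-methylphenyl in place of 2-cyanophenyl. Among the measured compounds shown here, the only measured step is a number 0.30 log units lower from compound 1 to compound 2 (within the scatter) for methyl in place of chloro, and it does not cover this exchange. A step from compound 3 cannot be sized. Compound 2, which also carries a methyl group, stands at 2.41 and serves as the anchor, with a somewhat lower number expected for compound 4. For the measured compounds named here, no measured compound carries a hydroxy group, so the range is kept wide. In this assay the expected value for compound 4 is 2.1 with an estimated range of 1.5 to 2.7 as its span.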

Compound 4, distribution coefficient: 1.85
The estimate for compound 4 lay 0.25 log units above the measured number; the measured number falls inside the stated range.
By their numbers in this assay, from the lowest: compound 4; then compounds 2 and 1 (each within the scatter of the next).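

In this assay, hydroxy in place of hydrogen on this aromatic ring gives a number 0.56 log units lower from compound 2 to compound 4 (beyond the scatter), so a change at this ring now moves the reading beyond the scatter, which methyl in place of chloro did not do. The exchange of 2-chlorophenyl for 4-hydroxy-2-methylphenyl gives a number 0.86 log units lower from compound 1 to compound 4 (beyond the scatter). No measurement shown here explains these shifts. On these data alone, whether an amine or a methoxy group in place of the hydroxy would move the reading as far remains open. Steps involving the nitrile of compound 3 cannot be read.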